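A methyl for a methoxy on a shared selenium-containing core

The source may hold more compounds than are shown below. What is called first, only, known or untested is meant among the compounds shown, and "the series" means these compounds.

Three compounds built on one core were tested in a functional assay on MCF7 cells (Homo sapiens) for antiproliferative activity, read by CCK-8 assay, with a stated time of 48 h; a lower number here means a stronger inhibitor, a higher number a weaker inhibitor. Compound 1 `COc1cc(-c2nnc(-n3[se]c4ccccc4c3=O)s2)cc(OC)c1OC` gives 3440 nM in this assay. Compound 2 `COc1ccc(-c2nnc(-n3[se]c4ccccc4c3=O)s2)cc1` gives 10000 nM, and compound 3 `O=c1c2ccccc2[se]n1-c1nnc(-c2ccccc2[N+](=O)[O-])s1` gives 31200 nM. Compound 2 thus stands second highest of the three numbers: compound 1 sits lower and compound 3 sits higher, and both gaps lie beyond the usual scatter of this assay.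

Compound 4 `Cc1ccc(-c2nnc(-n3[se]c4ccccc4c3=O)s2)cc1` has not yet been measured. It differs from compound 2 in one place: methyl in place of methoxy on an aromatic carbon. Among the compounds with values here, the change is small, and nothing among the three measured compounds shows how this assay answers to a methyl in place of a methoxy, since no pair that differs only there has been measured.

With no such comparison available, the expectation for compound 4 rests on compound 2 alone, and its reading in this assay is expected to stay close to that of compound 2, with a step of a 1.2-fold higher number from compound 2 to compound 4 (0.08 log units; within the scatter) that may well fall within the scatter or lean slightly toward a weaker inhibitor. The estimate for compound 4 in this assay is 12000 nM, expected to lie between 4000 nM and 40000 nM.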

Compound 4, half-maximal inhibitory concentration: 18700 nM
Compound 4: middle estimate off by 1.6-fold (0.19 log units), on the low side; the measured number falls inside the stated range.
By their numbers in this assay, from the lowest: compound 1; then compounds 2, 4 and 3 (each within the scatter of the next, the first and the last beyond it).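

Within the data shown here, this is the first pair on the shared core that differs in one place only, and this assay reads it as a 1.9-fold higher number from compound 2 to compound 4 (0.27 log units; within the scatter), with a methyl standing where compound 2 carries its methoxy. At this aromatic carbon, para to a large group, the oxygen and the one hydrogen-bond acceptor counted for methoxy can therefore leave without a step beyond the scatter, so this single pair does not tell compound 2 and compound 4 apart. Nothing available accounts for this reading or says what lies behind it.

The compounds shown leave open how far this position can be pushed: whether an amine, a hydroxyl, a carboxylic acid or a longer chain such as ethoxy on the same aromatic carbon would stay as close to compound 2, or would bring a step beyond the scatter in either direction. Among these compounds, they also leave open whether methyl in place of methoxy reads the same way on compound 1, which carries three methoxy groups, since the single pair here speaks only for the ring of compound 2.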